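Lengthening the chain from compound 2 to compound 4

This account rests on a few compounds, and the source may have more. Where it says the series, first, only, none or still open, it means among the compounds named here.

Values in a functional assay on A549 cells (Homo sapiens) for cytotoxicity, read by sulforhodamine B assay, with a stated time of 72 h (on this read-out higher numbers stand for weaker inhibition and lower numbers for stronger inhibition), are as follows:
Compound 1 `CCCC(=O)Nc1ccn([C@@H]2CO[C@H](CO)O2)c(=O)n1` gives 6600 nM
Compound 2 `CCCCC(=O)Nc1ccn([C@@H]2CO[C@H](CO)O2)c(=O)n1` gives 5230 nM
Compound 3 `CCCCCCCCC(=O)Nc1ccn([C@@H]2CO[C@H](CO)O2)c(=O)n1` gives 46 nM

Compound 2 gives 5230 nM as the second highest of the three numbers, level with the other high value (a 1.3-fold lower number from compound 1 to compound 2 (0.10 log units; within the scatter)). Compound 4 `CCCCCCCCCCCC(=O)Nc1ccn([C@@H]2CO[C@H](CO)O2)c(=O)n1` differs from it by a longer addition (heptyl in place of hydrogen on a saturated chain carbon, four bonds along the chain from a carbonyl carbon). The nearest guide is the butyl change at that same place, which led to compound 3 (a 110-fold lower number from compound 2 to compound 3 (2.06 log units; beyond the scatter)), and the pentyl change points the same way (a 140-fold lower number from compound 1 to compound 3 (2.16 log units; beyond the scatter)). No chain longer than that of compound 3 has been measured, so any further drop is unproven. A large step to a lower number is expected in this assay, an estimated 170-fold lower number from compound 2 to compound 4 (2.24 log units; beyond the scatter) overall. The estimate for compound 4 is 30 nM (expected range 7 nM to 130 nM).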

Compound 4, half-maximal inhibitory concentration: 15 nM
Compound 4: the middle estimate sits 2.0-fold (0.30 log units) above what was measured, and the stated range covers the measured number.
By their numbers in this assay, from the lowest: compound 4; then compound 3; then compounds 2 and 1 (each within the scatter of the next).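

In this assay, the chain longer than that of compound 3 still brought a further modest fall (a 3.1-fold lower number from compound 3 to compound 4 (0.49 log units; beyond the scatter)), so the drop did not end at compound 3. This last gain is small beside the whole change from the short chains (a 350-fold lower number from compound 2 to compound 4 (2.54 log units; beyond the scatter); a 440-fold lower number from compound 1 to compound 4 (2.64 log units; beyond the scatter)), most of which had already appeared at compound 3. No evidence on why the number falls with chain length is available here. From the compounds shown here alone, whether a longer chain would lower the number further or raise it again stays open, as does the effect of an amine or a carboxylic acid at the chain end.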